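The source may report more compounds than this note shows. Statements on the series, on what has been measured and on what is new or still open speak of the compounds shown alone.

Measured so far in a functional assay on the whole organism for positive allosteric modulation, with Mus musculus as the target; a lower number here means that less compound is needed, a higher number that more compound is needed for the effect:
- Compound 1 `CCC(=O)N(c1ccc(C)cc1)C1CCCC1N(C)C`: 30 mg/kg; 30 mg/kg (2 entries)
- Compound 2 `CCC(=O)N(c1cccc(F)c1)C1CCCC1N(C)C`: 0.4 mg/kg
- Compound 3 `CCC(=O)N(c1cccc(Cl)c1)C1CCCC1N(C)C`: 0.4 mg/kg

In this assay, compound 3 stands level with compound 2: compound 3 gives 0.4 mg/kg, and compound 2 gives 0.4 mg/kg. Compound 1 needs a much higher dose, at 30 mg/kg; 30 mg/kg (2 entries).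

Compound 4 `CCC(=O)N(c1ccc(C)c(Cl)c1)C1CCCC1N(C)C` departs from compound 3 by a single change: methyl in place of hydrogen on an aromatic carbon. The new methyl sits ortho to the chloro group and para to a large group.

Going by the values given here, the only measured step between close neighbours shows no change at the digits printed from compound 2 to compound 3 (within the scatter). It exchanges chloro for fluoro, so it gives no direct measure of what a methyl does. The nearest hint comes from two values. Compound 1, which has a methyl para to a large group and no chloro, gives 30 mg/kg; 30 mg/kg (2 entries), while compound 3, which has chloro and no methyl, gives 0.4 mg/kg. These two compounds differ in more than one place, so the comparison serves only as a warning, and the chloro of compound 4 may retain much of the low dose of compound 3.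

A moderate move towards a higher dose is therefore expected, smaller than the gap between those two values, and the estimated step is a 3.8-fold higher number from compound 3 to compound 4 (0.57 log units; beyond the scatter). For compound 4 the estimated value is 1.5 mg/kg. The expected range for compound 4 runs from 0.2 mg/kg to 15 mg/kg.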

Compound 4, dose for half-maximal effect: 1 mg/kg
For compound 4 the middle estimate is 1.5-fold (0.18 log units) above the measured one; low and high end bracket the measured number.
By their numbers in this assay, from the lowest: compounds 2 and 3 (each within the scatter of the next); then compound 4.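

In this assay the methyl in place of hydrogen, ortho to a chloro group and para to a large group, brings a 2.5-fold higher number from compound 3 to compound 4 (0.40 log units; beyond the scatter) and gives the first direct measure of what a methyl does at this position. With the chloro group absent, compound 1 gives 30 mg/kg; 30 mg/kg (2 entries) and with it present compound 4 gives 1 mg/kg so, among these two compounds, the one carrying both groups needs far less compound, and the methyl alone does not bring the number up to that of compound 1. No measured information is available to explain the size of this step.

The compounds shown leave open whether an ethyl, a methoxy or a trifluoromethyl group in place of this methyl would give a number closer to that of compound 3 or further from it, and how an amine or a carboxylic acid would read there. They also leave open whether the same methyl would bring a step of similar size with fluoro in place of the chloro group, as in compound 2.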